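Aryl swap on the triazole nitrogen: compound 3 to compound 4

The source may report more compounds than this note shows. Statements on the series, on what has been measured and on what is new or still open speak of the compounds shown alone.

Three compounds of this series share one core and differ only in the aryl group on an aromatic nitrogen. Compound 1 `Oc1cc(C(F)(F)F)ccc1-c1nc(-c2ccccc2O)n(-c2ccc(Br)cc2)n1` gives 69.4% in a functional assay on PC-12 cells (Rattus norvegicus) for cytotoxicity, read by MTT assay, with stated times of 2 h and 24 h, tested at 1 uM; on this read-out lower numbers stand for a weaker effect and higher numbers for a stronger effect at the one concentration tested. Compound 2 `Oc1cc(C(F)(F)F)ccc1-c1nc(-c2ccccc2O)n(-c2ccccc2F)n1` gives 63.4%. Compound 3 `Oc1cc(C(F)(F)F)ccc1-c1nc(-c2ccccc2O)n(-c2cccc(Cl)c2)n1` gives 72.3%, the largest of the three numbers, though the gaps to the other two are within the scatter: a number 2.9 percentage points higher from compound 1 to compound 3 (within the scatter) and a number 8.9 percentage points higher from compound 2 to compound 3 (within the scatter). The third measured step, a number 6 percentage points lower from compound 1 to compound 2 (within the scatter), is likewise within the scatter. All three steps exchange the aryl group on the aromatic nitrogen and none moves the read-out beyond the scatter.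

Compound 4 `Oc1cc(C(F)(F)F)ccc1-c1nc(-c2ccccc2O)n(-c2ccc(F)cc2F)n1` follows the same kind of change: 2,4-difluorophenyl in place of 3-chlorophenyl on an aromatic nitrogen. The three measured steps at this position all bear on it and none left the scatter, so the expectation for compound 4 is a step of no more than scatter size in either direction, a number 3.3 percentage points lower from compound 3 to compound 4 (within the scatter). Compound 4 is therefore estimated at 69%, within a range from 58% to 80%.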

Compound 4, a percentage reported as activity, at one concentration (the size of the read-out at that concentration, not a potency): 65.9%
Compound 4: the middle estimate sits 3.1 percentage points above what was measured; low and high end bracket the measured number.
By their numbers in this assay, from the lowest: compounds 2, 4, 1 and 3 (each within the scatter of the next).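

In this assay, among these compounds, the first aryl group here with two halogens stays level with the singly halogenated ones: a number 6.4 percentage points lower from compound 3 to compound 4 (within the scatter) and a number 3.5 percentage points lower from compound 1 to compound 4 (within the scatter). The series also gains its first step that alters a substituent on the aryl group instead of exchanging the whole group: fluoro in place of hydrogen on an aromatic carbon gives a number 2.5 percentage points higher from compound 2 to compound 4 (within the scatter), so this added fluoro leaves no effect that can be told from the scatter. No measurement on hand offers an explanation for these results.

Open, going by these compounds, is whether an aminophenyl or carboxyphenyl group, or a butyl chain in place of the aryl group, would also stay within the scatter. A single concentration also leaves open how these compounds would compare across a range of concentrations.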